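Compound 4: 4-hydroxyphenyl in place of 3-hydroxyphenyl

This account rests on a few compounds, and the source may have more. Where it says the series, first, only, none or still open, it means among the compounds named here.

Compound 1 `Oc1ccccc1-c1cc(-c2ccccc2)nc(-c2ccco2)c1`: 1900 nM
Compound 2 `Oc1cccc(-c2cc(-c3ccccc3)nc(-c3ccco3)c2)c1`: 24000 nM
Compound 3 `Oc1cccc(-c2cc(-c3ccccc3)nc(-c3ccncc3)c2)c1`: 12700 nM

In a functional assay on HL-60 cells (Homo sapiens) for cytotoxicity, read by ELISA, with a stated time of 2 days (on this read-out lower numbers stand for stronger inhibition and higher numbers for weaker inhibition), compound 2 lies at the weak end of these numbers. Pyridin-4-yl in place of furan-2-yl gives a 1.9-fold lower number from compound 2 to compound 3 (0.28 log units; within the scatter), so only compound 1 stands clearly apart. Compound 4 `Oc1ccc(-c2cc(-c3ccccc3)nc(-c3ccco3)c2)cc1` has 4-hydroxyphenyl in place of 3-hydroxyphenyl on an aromatic carbon, opposite the ring nitrogen (4-hydroxyphenyl in place of 3-hydroxyphenyl on an aromatic carbon). The most relevant measured change is 3-hydroxyphenyl in place of 2-hydroxyphenyl, which gave a 13-fold higher number from compound 1 to compound 2 (1.10 log units; beyond the scatter). Going by the values given here, this large step shows that the form of this group can matter, but no measurement yet covers 4-hydroxyphenyl. A modest, uncertain move towards lower numbers is expected. The expected step is a 2.2-fold lower number from compound 2 to compound 4 (0.34 log units; beyond the scatter). For compound 4 the estimated value is 11000 nM, within an expected range of 3000 nM to 35000 nM.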

Compound 4, half-maximal inhibitory concentration: 13700 nM
Compound 4: middle estimate off by 1.2-fold (0.10 log units), on the low side; measured number inside the range.
By their numbers in this assay, from the lowest: compound 1; then compounds 3, 4 and 2 (each within the scatter of the next).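

In this assay, shifting the hydroxyl from 3-hydroxyphenyl to 4-hydroxyphenyl makes no clear difference (a 1.8-fold lower number from compound 2 to compound 4 (0.24 log units; within the scatter)), while the change from 2-hydroxyphenyl to 4-hydroxyphenyl is clear (a 7.2-fold higher number from compound 1 to compound 4 (0.86 log units; beyond the scatter)). Among these three hydroxyphenyl groups at this position, opposite the ring nitrogen, only the 2-hydroxyphenyl of compound 1 therefore stands apart. Nothing available explains this difference.

On these data alone, it remains open what a methoxy group or an amine would do in place of the hydroxyl. Also open, as far as these compounds go, is whether 2-hydroxyphenyl keeps its lead when pyridin-4-yl replaces furan-2-yl.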